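Pyridin-4-yl in place of 4-fluorophenyl: expected edema inhibition

The compounds below may be only part of what the source reports. "The series", "measured", "known", "first", "only" and "open" are said of these compounds alone.

In a functional assay on the whole organism (strain Wistar) for inhibition, with Rattus norvegicus as the target, read by paw edema, with a stated time of 1 h, at a dose of 10 mg/kg by the intraperitoneal route (on this read-out lower numbers stand for less inhibition and higher numbers for more inhibition at the one dose given (going by the name of the read-out)), three compounds have been measured:
compound 1 `O=C(N/N=C/c1cccc(F)c1)c1cccnc1Nc1cccc(C(F)(F)F)c1`: 51.5%
compound 2 `O=C(N/N=C/c1ccc(F)cc1)c1cccnc1Nc1cccc(C(F)(F)F)c1`: 43.2%
compound 3 `COc1ccc(/C=N/NC(=O)c2cccnc2Nc2cccc(C(F)(F)F)c2)cc1OC`: 70%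

Compound 2 has the lowest of the three numbers. Its neighbour compound 1 is close: a number 8.3 percentage points lower from compound 1 to compound 2 (within the scatter). Compound 3 is further off: a number 26.8 percentage points higher from compound 2 to compound 3 (beyond the scatter), and likewise a number 18.5 percentage points higher from compound 1 to compound 3 (beyond the scatter).

Compound 4 `O=C(N/N=C/c1ccncc1)c1cccnc1Nc1cccc(C(F)(F)F)c1` is the next compound to be measured. Compared with compound 2 the change is pyridin-4-yl in place of 4-fluorophenyl on a carbon with a double bond to nitrogen. Among the measured compounds shown here, no measured step puts a pyridin-4-yl at this carbon, so the existing steps only frame what an exchange of the ring at this position can do: moving the fluorine gave a step within the scatter, while the 3,4-dimethoxyphenyl gave a modest gain. A heteroaromatic ring is a different kind of exchange, so the expected step is a number 3.8 percentage points higher from compound 2 to compound 4 (within the scatter), essentially none beyond the scatter. The estimate for compound 4 in this assay is 47%, with a likely range from 30% to 64%.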

Compound 4, a percentage reported as inhibition, in the whole organism at one dose (the size of the read-out at that dose, not a potency): 70.2%
Compound 4: the middle estimate sits 23.2 percentage points below what was measured; measured number outside the range, above it.
By their numbers in this assay, from the lowest: compounds 2 and 1 (each within the scatter of the next); then compounds 3 and 4 (each within the scatter of the next).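

In this assay, the ring on the carbon with a double bond to nitrogen can carry a ring nitrogen and still gain: pyridin-4-yl gives a number 27 percentage points higher from compound 2 to compound 4 (beyond the scatter), and in place of the other fluorinated ring it gives a number 18.7 percentage points higher from compound 1 to compound 4 (beyond the scatter). A gain at this position therefore does not require the 3,4-dimethoxyphenyl ring, for the smaller pyridin-4-yl ring stands level with it, with a number 0.2 percentage points higher from compound 3 to compound 4 (within the scatter). Nothing measured on these compounds offers an explanation for this result.

Still open, on these data alone, is whether the ring nitrogen must sit where pyridin-4-yl places it, a question that pyridin-3-yl at the same carbon could answer. Also open, as far as these compounds go, is whether a plain phenyl ring would stand with the two fluorinated compounds or with compound 3 and compound 4.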